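Chloro to hydrogen on the aryl of compound 2

A few compounds are considered here, and "the series" means these few. Any claim that something is new, unique, unknown or untested is made for them only; others in the source may bear on it.

Measured so far in an assay for displacement of a labelled ligand from Sigma non-opioid intracellular receptor 1 (Cavia porcellus); a higher number here means a weaker inhibitor, a lower number a stronger inhibitor: compound 1 `COC(=O)C1(c2ccc(C)cc2)CC1CN1CCC(Cc2ccccc2)CC1` gives 0.97 nM; compound 2 `COC(=O)C1(c2ccc(Cl)cc2)CC1CN1CCN(c2ccccn2)CC1` gives 707 nM; compound 3 `COC(=O)C1(c2ccccc2)CC1CN1CCC(Cc2ccccc2)CC1` gives 2.2 nM.

Compound 2 stands at the highest number of the three, well beyond the scatter from compound 3 and further still from compound 1. The step considered is compound 2 to compound 4 `COC(=O)C1(c2ccccc2)CC1CN1CCN(c2ccccn2)CC1`: hydrogen in place of chloro on an aromatic carbon. Going by the values given here, no measured pair shows chloro to hydrogen; the only step with a change on that aromatic carbon is a 2.3-fold higher number from compound 1 to compound 3 (0.36 log units; beyond the scatter), a methyl-to-hydrogen change on a different amine portion. Taking that as the nearest guide, a small rise in the number, or none beyond the scatter, is expected in this assay. Compound 4 is estimated at 1100 nM, range 400 nM to 3000 nM, an expected step of a 1.6-fold higher number from compound 2 to compound 4 (0.19 log units; within the scatter).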

Compound 4, inhibition constant: 1330 nM
For compound 4 the middle estimate is 1.2-fold (0.08 log units) below the measured one; low and high end bracket the measured number.
By their numbers in this assay, from the lowest: compound 1; then compound 3; then compounds 2 and 4 (each within the scatter of the next).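

In this assay, the change from 4-chlorophenyl to phenyl gives a 1.9-fold higher number from compound 2 to compound 4 (0.27 log units; within the scatter), so on the amine portion of compound 2 this place tolerates the loss of chloro without a step beyond the scatter. Going by these compounds alone, the only earlier change at this place, a 2.3-fold higher number from compound 1 to compound 3 (0.36 log units; beyond the scatter), involved methyl on a different amine portion and lay beyond the scatter. No supporting data bear on why these two steps read differently.

Open, going by these compounds, is whether chloro on the amine portion of compound 3 would read as it does here. Also open, on these data alone, is how a larger group, such as methoxy or a carboxylic acid, would read at this place.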